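The source may report more compounds than this note shows. Statements on the series, on what has been measured and on what is new or still open speak of the compounds shown alone.

Compound 1 `COc1cccc(CNCCCNc2ccnc3cc(Oc4ccc(Cl)cc4)ccc23)c1O`: 14500 nM
Compound 2 `COc1cccc(CNCCCNc2ccnc3cc(Oc4cccc(N(C)C)c4)ccc23)c1O`: 14500 nM
Compound 3 `CN(C)c1cccc(Oc2ccc3c(NCCCNCc4ccco4)ccnc3c2)c1`: 14500 nM

In a physicochemical assay for solubility, with a stated time of 18 h, at pH 7.4 (a higher number here means a more soluble compound, a lower number a less soluble compound), compound 2 gives 14500 nM, level with compounds 1 and 3 at the digits shown; its nearest neighbour is compound 1, its furthest compound 3, and neither gap is beyond the scatter. Compound 4 `COc1ccccc1Oc1ccc2c(NCCCNCc3cccc(OC)c3O)ccnc2c1` has not yet been measured. Its difference from compound 2 is 2-methoxyphenyl in place of 3-(dimethylamino)phenyl on an oxygen on an aromatic ring.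

Within the data shown here, of the measured steps, the one most like this change is no change at the digits printed from compound 1 to compound 2 (within the scatter), which also exchanges an aryl group on the same oxygen on an aromatic ring. The other, no change at the digits printed from compound 2 to compound 3 (within the scatter), touches a different place, the saturated chain carbon bound to an amine nitrogen, and is also flat. Neither step gives a reason to expect movement. For compound 4 the expected step is therefore no change at the digits printed from compound 2 to compound 4 (within the scatter), none beyond the scatter in either direction. The estimated solubility of compound 4 in this assay is 14500 nM, with a range from 7000 nM to 29000 nM.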

Compound 4, solubility: 14500 nM
Compound 4: the middle estimate sits on the measured number at the digits printed; low and high end bracket the measured number.
By their numbers in this assay, from the lowest: compounds 1, 2, 3 and 4 (each within the scatter of the next).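

In this assay the exchange of 3-(dimethylamino)phenyl for 2-methoxyphenyl gives no change at the digits printed from compound 2 to compound 4 (within the scatter) and the exchange of 4-chlorophenyl for 2-methoxyphenyl gives no change at the digits printed from compound 1 to compound 4 (within the scatter) as well. Among these compounds, the earlier compounds had compared only two aryl groups on this oxygen on an aromatic ring, whereas three can now be compared, and the entering group carries an oxygen where the leaving 3-(dimethylamino)phenyl carries a nitrogen. No step among these three groups lies beyond the scatter.

The compounds shown do not tell whether a carboxylic acid or a piperidine ring at this place would move the read-out in this assay at all. The data offer no measurement that could account for these identical values.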